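The compounds below may be only part of what the source reports. "The series", "measured", "known", "first", "only" and "open" are said of these compounds alone.

Compounds measured so far in a functional assay on MCF7 cells (Homo sapiens) for cytotoxicity, read by MTT assay, with a stated time of 72 h; on this read-out lower numbers stand for stronger inhibition and higher numbers for weaker inhibition:

Compound 1 `Cc1cc(-c2ccccc2)n(/C(N)=N/S(=O)(=O)c2cc(C)c(Cl)cc2SCc2cccc3ccccc23)n1`: 170000 nM
Compound 2 `Cc1cc(-c2ccccc2)n(/C(N)=N/S(=O)(=O)c2cc(C)c(Cl)cc2SCc2cccc(C(F)(F)F)c2)n1`: 41000 nM
Compound 3 `Cc1cc(-c2ccccc2)n(/C(N)=N/S(=O)(=O)c2cc(C)c(Cl)cc2SCc2ccccc2C)n1`: 80000 nM

All three share the same core and differ only in the aromatic group attached to the saturated chain carbon bound to the sulfur. Among these numbers, compound 3 stands second highest. Its nearest neighbour is compound 2, and that difference, a 2.0-fold higher number from compound 2 to compound 3 (0.29 log units; within the scatter), is within the scatter, so the two cannot be ranked against each other. The furthest is compound 1: the step of a 2.1-fold lower number from compound 1 to compound 3 (0.33 log units; beyond the scatter) is modest but beyond the scatter. The remaining measured step, a 4.1-fold lower number from compound 1 to compound 2 (0.62 log units; beyond the scatter), is likewise modest.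

Compound 4 `Cc1cc(-c2ccccc2)n(/C(N)=N/S(=O)(=O)c2cc(C)c(Cl)cc2SCc2ccccc2Cl)n1` is the next compound to be measured. It differs from compound 3 by chloro in place of methyl on an aromatic carbon. Among the measured compounds shown here, none of the measured steps bears directly on this kind of change: each of them swapped the whole aromatic group rather than one small group on it. For the measured compounds named here, the one step that kept a six-membered ring and changed only what sits on it, from compound 2 to compound 3, stayed within the scatter. On this basis the expected step in this assay is no change at the digits printed from compound 3 to compound 4 (within the scatter). That would be nothing beyond the scatter. Compound 4 is therefore estimated at 80000 nM, in the range 30000 nM to 200000 nM.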

Compound 4, half-maximal inhibitory concentration: 135000 nM
Compound 4: the middle estimate sits 1.7-fold (0.23 log units) below what was measured, and the stated range covers the measured number.
By their numbers in this assay, from the lowest: compounds 2, 3, 4 and 1 (each within the scatter of the next, the first and the last beyond it).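

In this assay, this is the only step shown that exchanges one small group on an aromatic carbon while leaving the rest of the compound untouched: with chloro in place of methyl, ortho to a large group, a 1.7-fold higher number from compound 3 to compound 4 (0.23 log units; within the scatter) lies within the scatter, so these two groups cannot be ranked at this position. The whole-group comparisons add to this, since a 1.3-fold lower number from compound 1 to compound 4 (0.10 log units; within the scatter) also lies within the scatter and leaves 2-chlorophenyl and naphthalen-1-yl unranked, whereas a 3.3-fold higher number from compound 2 to compound 4 (0.52 log units; beyond the scatter) is modest but beyond the scatter and separates 2-chlorophenyl from 3-(trifluoromethyl)phenyl. No measurement is available that would explain these numbers.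

From the compounds shown here alone, it remains open whether an amine, a hydroxyl or a carboxylic acid on that same aromatic carbon would give a number beyond the scatter from compound 3. Also unresolved is whether the gap between compound 2 and compound 4 belongs to the trifluoromethyl group itself or to where it sits on the ring, as no compound shown carries chloro and trifluoromethyl at the same place.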